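The compounds below may be only part of what the source reports. "The series", "measured", "known", "first", "only" and "open" are said of these compounds alone.

Compound 2 `C=CCNc1ccc(C(=O)N2CCCCc3ccccc32)c(Cl)c1` gives 5.9 nM in an assay on HeLa cells for binding affinity to Vasopressin V2 receptor (Homo sapiens) (on this read-out higher numbers stand for weaker inhibition and lower numbers for stronger inhibition), the lowest of the three numbers recorded so far. Its nearest neighbour is compound 3 `O=C(c1ccc(N2CCCC2)cc1Cl)N1CCCCc2cc(Cl)ccc21`, which gives 16 nM in this assay, and the furthest is compound 1 `CCN(CC)c1ccc(C(=O)N2CCCCc3ccccc32)c(Cl)c1`, which gives 19 nM. Among the compounds with values here, the only single-point step among the measured compounds is a 3.2-fold lower number from compound 1 to compound 2 (0.51 log units; beyond the scatter), where allylamino took the place of diethylamino on an aromatic carbon. Compound 4 `Cc1ccn(-c2ccc(C(=O)N3CCCCc4ccccc43)c(Cl)c2)n1` differs from compound 2 at that same place: 3-methyl-1H-pyrazol-1-yl in place of allylamino on an aromatic carbon. Within the data shown here, the one step that bears on this change was modest, and it concerned two open-chain amino groups, whereas here an aromatic ring enters and the hydrogen-bond donor is lost. Among the measured compounds shown here, compound 3 also carries a ring at this place but differs from compound 2 in a second position as well, so its higher number offers no clean precedent. The analyst therefore expects a small rise in number, a 2.5-fold higher number from compound 2 to compound 4 (0.41 log units; beyond the scatter). For compound 4 the estimate in this assay is 15 nM, within 5 nM to 45 nM.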

Compound 4, half-maximal inhibitory concentration: 13 nM
Beside the measured number, compound 4's estimate is 1.2-fold (0.06 log units) above it; measured number inside the range.
By their numbers in this assay, from the lowest: compound 2; then compounds 4, 3 and 1 (each within the scatter of the next).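

With 3-methyl-1H-pyrazol-1-yl at this place, para to a large group, the position is shown to accept a five-membered aromatic ring with 2 hetero atoms and 0 hydrogen-bond donors in this assay, with a 2.2-fold higher number from compound 2 to compound 4 (0.34 log units; beyond the scatter) as the price against allylamino. Against diethylamino the same ring gives a 1.5-fold lower number from compound 1 to compound 4 (0.16 log units; within the scatter) and so stands level with it, which leaves allylamino as the only one of these three groups set apart from the other two. Nothing given here explains why the numbers fall this way.

The compounds shown do not separate the double bond of allylamino from its amino hydrogen. Propylamino or dimethylamino at this place would separate the two. The compounds shown also leave open whether the methyl on the pyrazole counts, as a plain 1H-pyrazol-1-yl or an imidazol-1-yl group would show.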